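This account rests on a few compounds, and the source may have more. Where it says the series, first, only, none or still open, it means among the compounds named here.

In a functional assay on the whole organism (strain Sprague-Dawley) for inhibition, with Rattus norvegicus as the target, with a stated time of 10 min (a higher number here means that more compound is needed for the effect, a lower number that less compound is needed), compound 1 `COc1cccc(-c2ncc(C(=O)O)c(=O)[nH]2)c1` gives 10 mg/kg, while compound 2 `CCOc1ccc(OC)cc1-c1ncc(C(=O)O)c(=O)[nH]1` gives 0.2 mg/kg, the lowest of the two numbers. Compound 3 `CCOc1ccc(N)cc1-c1ncc(C(=O)O)c(=O)[nH]1` carries amino in place of methoxy on an aromatic carbon, para to an ethoxy group: amino in place of methoxy on an aromatic carbon. For the measured compounds named here, the only measured step, a 50-fold lower number from compound 1 to compound 2 (1.70 log units; beyond the scatter), is large, but it introduced the ethoxy group, which compound 3 keeps, and no measured step replaces methoxy. A far smaller rise in this assay is therefore expected, an estimated 2.5-fold higher number from compound 2 to compound 3 (0.40 log units; beyond the scatter). For compound 3 the expected value is 0.5 mg/kg, with an estimated range of 0.1 mg/kg to 3 mg/kg.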

Compound 3, dose for 50% inhibition: 1.2 mg/kg
For compound 3 the middle estimate is 2.4-fold (0.38 log units) below the measured one; the measured number falls inside the stated range.
By their numbers in this assay, from the lowest: compound 2; then compound 3; then compound 1.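

In this assay, amino in place of methoxy gives a 6.0-fold higher number from compound 2 to compound 3 (0.78 log units; beyond the scatter), so this position, para to an ethoxy group, is not indifferent to what it carries. The change swaps methoxy for a smaller group with a hydrogen-bond donor, and the number stays in the low range of the series, though the step is modest and beyond the scatter. Nothing at hand accounts for this rise. The compounds shown leave open how a hydroxyl, a dimethylamino or an acetamido group would fare here, and whether a longer chain such as propoxy would bring the number below that of compound 2.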